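A Fluoro-for-Methoxy Swap Beside an Unchanged Amide

The source may report more compounds than this note shows. Statements on the series, on what has been measured and on what is new or still open speak of the compounds shown alone.

For the measured compounds named here, compound 3 `C=CC1=C(C(=O)NC2CCCCC2)C(c2ccc(OC)cc2)OC1` is the only member of this small set to give a number in a functional assay on HeLa cells (Homo sapiens) for cytotoxicity, read by MTT assay, with a stated time of 24 h; a higher number here means a weaker inhibitor, a lower number a stronger inhibitor; there compound 3 gives 24800 nM. Compound 1 `C=CC1=C(C(=O)NCc2ccc(Cl)cc2)C(c2ccc(OC)cc2)OC1` reaches only a limit of the assay, > 100000 nM. Compound 2 `C=CC1=C(C(=O)NC(C)(C)C)C(c2ccc(OC)cc2)OC1` likewise reaches only a limit, > 100000 nM. The two measured steps that can be read, an at least 4.0-fold lower number from compound 1 to compound 3 (0.60 log units; beyond the scatter) and an at least 4.0-fold lower number from compound 2 to compound 3 (0.60 log units; beyond the scatter), both concern the group on the amide-type nitrogen and both favour cyclohexyl; the step that the two limits leave unreadable from compound 1 to compound 2 cannot be read because of the limit of > 100000 nM in this assay, at which 2 of the 3 values shown sit. Compound 4 `C=CC1=C(C(=O)NC2CCCCC2)C(c2ccc(F)cc2)OC1` keeps the cyclohexyl amide and changes the other end: fluoro in place of methoxy on an aromatic carbon, so that the 4-methoxyphenyl becomes 4-fluorophenyl. Going by the values given here, no measured step touches this position, so the measured steps give no guide to the size or direction of this one. The account therefore expects the step of a 1.0-fold higher number from compound 3 to compound 4 (0.00 log units; within the scatter) to stay within the scatter. Compound 4 is estimated at 25000 nM, between 8000 nM and 80000 nM.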

Compound 4, half-maximal inhibitory concentration: > 100000 nM
Compound 4 ended at the assay's limit (the forecaster's own chance of this, stated with the estimate: 25%); middle value at least 4.0-fold (0.60 log units) away from the limit.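

With the cyclohexyl amide unchanged, fluoro in place of methoxy gives an at least 4.0-fold higher number from compound 3 to compound 4 (0.60 log units; beyond the scatter) in this assay, so this aromatic position also bears on the read-out, not only the group on the amide-type nitrogen. Among the compounds shown, only compound 3, which combines the cyclohexyl amide with the 4-methoxyphenyl, gives a number, while compound 1, compound 2 and compound 4 each differ from it in one place and do not. The step is a bound rather than a size, since compound 4 reaches only a limit of the assay: the limit of > 100000 nM in this assay, at which 3 of the 4 values shown sit.

As far as these compounds go, how far compound 4 lies beyond that limit remains open. Also open, from the compounds shown here alone, is what an ethoxy, a hydroxyl or an amine would give in place of methoxy on the same aromatic carbon, with the cyclohexyl amide kept.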